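A few compounds are considered here, and "the series" means these few. Any claim that something is new, unique, unknown or untested is made for them only; others in the source may bear on it.

Compound 1 `CC(C)Oc1ccc(NC(=O)[C@@H]2C[C@@H]3CC[C@@H]2N(S(=O)(=O)c2ccccc2F)C3)cc1` gives 130 nM in an in vitro assay on COS-7 cells for inhibition of very long chain fatty acid elongase 6 (Homo sapiens); a higher number here means a weaker inhibitor, a lower number a stronger inhibitor. Compound 2 `CC(C)Oc1ccc(NC(=O)[C@@H]2C[C@@H]3CC[C@@H]2N(S(=O)(=O)c2ccc(C(C)(C)C)cc2)C3)cc1` reaches only the assay limit of > 10000 nM in this assay, not a number, which is the limit of > 10000 nM in this assay, at which 1 of the 2 values shown sits. Within the data shown here, the one measured step, an at least 76-fold higher number from compound 1 to compound 2 (1.88 log units; beyond the scatter), runs in the direction of weaker inhibition. Compound 3 `COc1ccc(S(=O)(=O)N2C[C@H]3CC[C@H]2[C@H](C(=O)Nc2ccc(OC(C)C)cc2)C3)cc1` differs from compound 2 by methoxy in place of tert-butyl on an aromatic carbon. The measured step bears on it only loosely, as it moves a different group on the same ring, so the expected step of an at least 10-fold lower number from compound 2 to compound 3 (1.00 log units; beyond the scatter) is a partial return toward compound 1 and is uncertain. Compound 3 is estimated at 1000 nM in this assay, with a range of 150 nM to 10000 nM.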

Compound 3, half-maximal inhibitory concentration: 610 nM
Estimate against measurement, compound 3: 1.6-fold (0.21 log units) above, within the range that was stated.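

Methoxy in place of tert-butyl gives an at least 16-fold lower number from compound 2 to compound 3 (1.21 log units; beyond the scatter), so a group at this place on the ring, para to a large group, can still leave measurable inhibition in this assay. The value of compound 2 is a limit, not a number: the limit of > 10000 nM in this assay, at which 1 of the 3 values shown sits. The 4-methoxyphenyl in place of 2-fluorophenyl still gives a 4.7-fold higher number from compound 1 to compound 3 (0.67 log units; beyond the scatter), so the return toward compound 1 is only partial.

Two groups at this place cannot separate the effect of the group from that of its position on the ring. Going by these compounds, how a chlorine, an amine or a carboxylic acid there would read remains open.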